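The compounds below may be only part of what the source reports. "The series", "measured", "known", "first", "only" and "open" are said of these compounds alone.

Working notes on the diaryl urea series in a functional assay on SF-539 cells (Homo sapiens) for inhibition, read by sulforhodamine B assay, with a stated time of 48 h; on this read-out lower numbers stand for stronger inhibition of growth and higher numbers for weaker inhibition of growth.

Compound 1 `COc1cc2cc(Oc3ccc(NC(=O)Nc4cccc(C(F)(F)F)c4)cc3)c(C)nc2cc1OC` gives 2480 nM. Compound 2 `COc1cc2cc(Oc3ccc(NC(=O)Nc4ccc(Cl)c(C(F)(F)F)c4)cc3)c(C)nc2cc1OC` gives 1960 nM. Within the data shown here, the only step between measured compounds, a 1.3-fold lower number from compound 1 to compound 2 (0.10 log units; within the scatter), adds a chloro at an aromatic carbon; compound 2 therefore holds the lowest of the two numbers, but its gap to compound 1 sits within the scatter, so no order can be read.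

Compound 3 `COc1cc2cc(Oc3ccc(NC(=O)Nc4ccc(Cl)c(Cl)c4)cc3)c(C)nc2cc1OC` is not yet measured. It differs from compound 2 by chloro in place of trifluoromethyl on an aromatic carbon. Among the measured compounds shown here, no measured step swaps a trifluoromethyl for a chloro, so nothing bears directly on this change; the one measured step, a 1.3-fold lower number from compound 1 to compound 2 (0.10 log units; within the scatter), shows only that a small change at this ring moved the number little. The step of a 1.0-fold higher number from compound 2 to compound 3 (0.01 log units; within the scatter) is accordingly expected to stay within the scatter, with no direction claimed. Compound 3 is estimated at 2000 nM, between 800 nM and 5000 nM.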

Compound 3, concentration for 50% growth inhibition: 5180 nM
The estimate for compound 3 lay 2.6-fold (0.41 log units) below the measured number, outside the stated range (above it).
By their numbers in this assay, from the lowest: compounds 2 and 1 (each within the scatter of the next); then compound 3.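

In this assay the step of a 2.6-fold higher number from compound 2 to compound 3 (0.42 log units; beyond the scatter) reads beyond the scatter, so chloro in place of trifluoromethyl on this aromatic carbon, ortho to a chloro group, matters more here than the earlier chloro step suggested. The wider change, 3,4-dichlorophenyl in place of 3-(trifluoromethyl)phenyl, gives the same picture with a 2.1-fold higher number from compound 1 to compound 3 (0.32 log units; beyond the scatter) and is also modest in size, so among these three compounds the two that carry trifluoromethyl hold the lower numbers. No measurement on hand accounts for this difference.

Open, on these data alone, is whether the trifluoromethyl itself is what counts at this carbon, or whether other groups would hold the number as well. A methoxy, a nitrile or a bromo at the same place would separate these readings.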